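A Benzodioxinyl Replacement at the Biaryl Position

The source may hold more compounds than are shown below. What is called first, only, known or untested is meant among the compounds shown, and "the series" means these compounds.

Compound 1 `CC(C(=O)NCc1ccc(C(F)(F)F)nc1-c1ccc(C(C)(C)C)cc1)c1ccc(NS(C)(=O)=O)c(F)c1` gives 0.5 nM in an assay on CHO cells for antagonist activity at transient receptor potential cation channel subfamily V member 1 (Homo sapiens), read by FLIPR; a lower number here means a stronger inhibitor, a higher number a weaker inhibitor.
Compound 2 `COc1ccc(-c2nc(C(F)(F)F)ccc2CNC(=O)C(C)c2ccc(NS(C)(=O)=O)c(F)c2)cc1F` gives 4.2 nM in this assay.

Of the two measured compounds, compound 2 stands at the highest number; its nearest neighbor is compound 1, separated by the step of an 8.4-fold higher number from compound 1 to compound 2 (0.92 log units; beyond the scatter), which came from putting 3-fluoro-4-methoxyphenyl in place of 4-(tert-butyl)phenyl on an aromatic carbon.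

Compound 3 `CC(C(=O)NCc1ccc(C(F)(F)F)nc1-c1ccc2c(c1)OCCO2)c1ccc(NS(C)(=O)=O)c(F)c1` differs from compound 2 in one place: 2,3-dihydro-1,4-benzodioxin-6-yl in place of 3-fluoro-4-methoxyphenyl on an aromatic carbon. Within the data shown here, the only measured step, an 8.4-fold higher number from compound 1 to compound 2 (0.92 log units; beyond the scatter), concerns a different exchange at this same aromatic carbon and shows that the position tolerates a change of the attached aryl group with a modest shift. Among the measured compounds shown here, no measured pair compares a 3-fluoro-4-methoxyphenyl group with a 2,3-dihydro-1,4-benzodioxin-6-yl group, so the direction for compound 3 cannot be read from the data. Compound 3 is therefore expected to land close to compound 2, with a step of a 1.1-fold higher number from compound 2 to compound 3 (0.03 log units; within the scatter) that may stay within the scatter. The estimate for compound 3 in this assay is 4.5 nM, expected to fall between 1.5 nM and 14 nM.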

Compound 3, inhibition constant: 5 nM
Compound 3: middle estimate off by 1.1-fold (0.05 log units), on the low side; measured number inside the range.
By their numbers in this assay, from the lowest: compound 1; then compounds 2 and 3 (each within the scatter of the next).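

In this assay, the new exchange gives a 1.2-fold higher number from compound 2 to compound 3 (0.08 log units; within the scatter), so at this aromatic carbon next to the ring nitrogen, the 2,3-dihydro-1,4-benzodioxin-6-yl and 3-fluoro-4-methoxyphenyl groups cannot be told apart. Set against the 4-(tert-butyl)phenyl group, the new group gives a 10-fold higher number from compound 1 to compound 3 (1.00 log units; beyond the scatter), which makes compound 3 the second replacement, after compound 2, to lie beyond the scatter from compound 1, and compound 1 keeps the lowest number of the three. No measurement at hand accounts for either step.

The compounds shown leave open whether a smaller alkyl group on the phenyl ring, such as isopropyl in place of tert-butyl, would stay close to compound 1 at 0.5 nM or fall in with the two oxygen-bearing replacements. They also leave open how this position responds when the attached aryl group gives way to something of another kind, such as a piperidine ring or an open-chain amine.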